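The source may report more compounds than this note shows. Statements on the series, on what has been measured and on what is new or still open speak of the compounds shown alone.

Compound 1 `Oc1ccc(CNc2ncnc3c2ncn3C2CCCCO2)cc1`: > 100000 nM
Compound 2 `COc1cc(CNc2ncnc3c2ncn3C2CCCCO2)ccc1O`: > 100000 nM
Compound 3 `COc1ccc(OC)c(CNc2ncnc3c2ncn3C2CCCCO2)c1`: 16500 nM

All three compounds were tested in an ADME assay on K562 cells (Homo sapiens) for cytotoxicity, with a stated time of 72 h; a lower number here means a stronger inhibitor, a higher number a weaker inhibitor. The entry for compound 1 is a limit of the assay and not a number. It stands at the limit of > 100000 nM in this assay, at which 2 of the 3 values shown sit, so its place among the three cannot be fixed exactly. Compound 3 alone gives a number, 16500 nM.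

Among the compounds with values here, the only measured step that changes one place is a step that the two limits leave unreadable from compound 1 to compound 2, with methoxy in place of hydrogen on an aromatic carbon. It offers no size to carry forward.

The next compound is compound 4 `Oc1cc(O)cc(CNc2ncnc3c2ncn3C2CCCCO2)c1`. Its difference from compound 1 is 3,5-dihydroxyphenyl in place of 4-hydroxyphenyl on a saturated chain carbon bound to a nitrogen on an aromatic ring.

Among these three compounds, the two that carry a hydroxy group end at the limit, and compound 3, which has none, gives a number. Compound 4 keeps hydroxy groups, so no step beyond the scatter is expected, and another limit is the likeliest report. The expected change is an at least 1.1-fold lower number from compound 1 to compound 4 (0.04 log units; that floor lies within the scatter). For compound 4 the estimated value is 90000 nM, with an expected range from 30000 nM to 200000 nM.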

Compound 4, half-maximal inhibitory concentration: > 100000 nM
Compound 4 was reported as a limit (the forecaster's own chance of this, stated with the estimate: 65%); at least 1.1-fold (0.04 log units) between middle value and limit.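

In this assay compound 4 gives > 100000 nM, which is a limit of the assay and not a number. Compound 1 also stands at a limit, and no step from compound 1 to compound 4 can be read: the limit of > 100000 nM in this assay, at which 3 of the 4 values shown sit.

The compounds shown leave open how compound 1, compound 2 and compound 4 rank against one another.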